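Working notes on a small inhibition series

The compounds below may be only part of what the source reports. "The series", "measured", "known", "first", "only" and "open" are said of these compounds alone.

Measured so far:
compound 1 `Nc1nc2cc(Cl)c(Cl)cc2n1Cc1ccc(Cl)cc1`, 45000 nM
compound 2 `Nc1nc2cc(Cl)c(Cl)cc2n1Cc1ccc(Cl)c(Cl)c1`, 35000 nM
compound 3 `Clc1ccc(Cn2c(Br)nc3cc(Cl)c(Cl)cc32)cc1Cl`, reported only as a limit, > 100000 nM

In a functional assay on KB cells (Homo sapiens) for inhibition (on this read-out lower numbers stand for stronger inhibition and higher numbers for weaker inhibition), compound 2 gives 35000 nM and compound 1 gives 45000 nM. The change between them, (hydrogen in place of chloro on an aromatic carbon), produced a 1.3-fold higher number from compound 2 to compound 1 (0.11 log units; within the scatter). For compound 3 this assay gives only a limit, > 100000 nM; this is the limit of > 100000 nM in this assay, at which 1 of the 3 values shown sits. The two cores differ by bromo in place of amino on an aromatic carbon, which produced an at least 2.8-fold higher number from compound 2 to compound 3 (0.45 log units; beyond the scatter).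

Compound 4 `Clc1cccc(Cn2c(Br)nc3cc(Cl)c(Cl)cc32)c1` has not been measured. It differs from compound 3 by hydrogen in place of chloro on an aromatic carbon. This is the same kind of change as from compound 2 to compound 1, with the place para to a large group here rather than meta to a large group there. In this assay compound 4 is expected to stay at or beyond the limit, the estimated step being a step that the limit leaves unreadable from compound 3 to compound 4. That expectation rests on the earlier step of a 1.3-fold higher number from compound 2 to compound 1 (0.11 log units; within the scatter), which remained within the scatter. Compound 4 is therefore estimated at 150000 nM, with a range from 60000 nM to 400000 nM, most likely again reported only as a limit.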

Compound 4, half-maximal inhibitory concentration: > 100000 nM
Compound 4: a limit, no number; the forecaster's own chance of this, stated with the estimate: 80%; the middle value does not contradict the limit.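

In this assay, compound 4 gives only a limit, > 100000 nM, and compound 3 is also held at a limit, so no step from compound 3 to compound 4 can be read: the limit of > 100000 nM in this assay, at which 2 of the 4 values shown sit.

The compounds shown leave open how far past that limit compound 3 and compound 4 lie, and whether hydrogen in place of chloro changes anything in the core of compound 3.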